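Ester variation on a shared dihydropyridine-type series

This account rests on a few compounds, and the source may have more. Where it says the series, first, only, none or still open, it means among the compounds named here.

Measured so far in an assay on isolated protein (strain albino) for antagonist activity at Voltage-dependent L-type calcium channel subunit alpha-1C (Cavia porcellus); on this read-out higher numbers stand for weaker inhibition and lower numbers for stronger inhibition:
compound 1 `CCCOC(=O)C1=C(C)NC(C)=C(C(=O)OCCC)C1c1cnc(SC)n1Nc1ccccc1` — 2.29 nM
compound 2 `CSc1ncc(C2C(C(=O)OC(C)C)=C(C)NC(C)=C2C(=O)OC(C)C)n1Nc1ccccc1` — 2.16 nM
compound 3 `CSc1ncc(C2C(C(=O)OCc3ccccc3)=C(C)NC(C)=C2C(=O)OCc2ccccc2)n1Nc1ccccc1` — 1.49 nM

The three compounds share one core and differ only in the two ester groups. All three numbers sit close together: compound 2 stands second highest of the three, with compound 1 nearest and compound 3 furthest, and both gaps lie within the usual scatter of this assay. Between compounds 1, 2 and 3 no single-point step can be drawn, so the values show only that propyl, isopropyl and benzyl esters give numbers of the same order.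

Compound 4 `COCCOC(=O)C1=C(C)NC(C)=C(C(=O)OC(C)C)C1c1cnc(SC)n1Nc1ccccc1` keeps one isopropyl ester of compound 2 and changes the other: 2-methoxyethyl in place of isopropyl on an oxygen next to a carbonyl group. Among the measured compounds shown here, no step between measured compounds of this kind exists, so the expectation rests on the narrow spread seen for compounds 1 to 3. The step from compound 2 to compound 4 is estimated as a 1.2-fold higher number from compound 2 to compound 4 (0.06 log units; within the scatter), that is, no change beyond the scatter in either direction. For compound 4 the value in this assay is estimated at 2.5 nM, with a range from 1 nM to 6 nM.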

Compound 4, half-maximal inhibitory concentration: 53.4 nM
Compound 4: the middle estimate sits 21-fold (1.33 log units) below what was measured; the whole stated range lies below it.
By their numbers in this assay, from the lowest: compounds 3, 2 and 1 (each within the scatter of the next); then compound 4.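

In this assay, 2-methoxyethyl in place of isopropyl on an oxygen next to a carbonyl group gives a 25-fold higher number from compound 2 to compound 4 (1.39 log units; beyond the scatter), a large step, so this ester position is sensitive to the group it carries. Among the compounds shown here, compounds 1 to 3 could not show this: each carries one group on both esters, and no single-place step links them. For the compounds shown here, the entering group brings 4 heavy atoms against 3 and 1 hydrogen-bond acceptor against 0, but the one step cannot separate these differences, and no independent measurement bears on the origin of the loss.

Open, going by these compounds, is whether the step follows the ether oxygen or the longer chain: a butyl ester paired with the isopropyl ester would separate the two. Also open, on these data alone, is how far the step extends to other groups at this position, such as a 2-aminoethyl ester or a carboxylic acid, and whether 2-methoxyethyl on both esters goes further than compound 4.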